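Swapping an Open Amine for a Pyrrolidine Ring

The compounds below may be only part of what the source reports. "The series", "measured", "known", "first", "only" and "open" are said of these compounds alone.

Three measured compounds share one core: compound 1 `COc1cc2c(Nc3nc4ccc(C(=O)Nc5c(C)cccc5Cl)cc4s3)ncnc2cc1OCCCN1CCCCC1C`, compound 2 `COc1cc2c(Nc3nc4ccc(C(=O)Nc5c(C)cccc5C)cc4s3)ncnc2cc1OCCCN1CCCC1` and compound 3 `CCN(CC)CCCOc1cc2ncnc(Nc3nc4ccc(C(=O)Nc5c(C)cccc5Cl)cc4s3)c2cc1OC`. They differ mainly in the amine that sits on a saturated chain carbon, three bonds along the chain from an oxygen on an aromatic ring. In a functional assay on DLD-1 cells (Homo sapiens) for cytotoxicity, read by WST assay, with a stated time of 72 h (a higher number here means a weaker inhibitor, a lower number a stronger inhibitor), compound 1 gives 6700 nM and compound 3 gives 11700 nM. Compound 3 thus holds the higher of the two numbers, yet the step of a 1.7-fold higher number from compound 1 to compound 3 (0.24 log units; within the scatter) stays within the scatter, so the two cannot be ranked. Compound 2 reaches only a limit of the assay, > 100000 nM; this is the limit of > 100000 nM in this assay, at which 1 of the 3 values shown sits.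

Compound 4 `COc1cc2c(Nc3nc4ccc(C(=O)Nc5c(C)cccc5Cl)cc4s3)ncnc2cc1OCCCN1CCCC1` has not yet been measured. Against compound 3 the change is pyrrolidin-1-yl in place of diethylamino on a saturated chain carbon, three bonds along the chain from an oxygen on an aromatic ring. Going by the values given here, the one measured step at this place, a 1.7-fold higher number from compound 1 to compound 3 (0.24 log units; within the scatter), exchanged one ring amine for the open diethylamino group without moving beyond the scatter, so returning to a small ring amine is expected to change little. Compound 2 also carries pyrrolidin-1-yl, but it differs at a second site as well, so its limit gives no direct guide. The expected step of a 1.2-fold lower number from compound 3 to compound 4 (0.07 log units; within the scatter) is therefore small. Compound 4 is estimated at 10000 nM, with a likely range from 3500 nM to 35000 nM.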

Compound 4, half-maximal inhibitory concentration: 60700 nM
Compound 4: middle estimate off by 6.1-fold (0.78 log units), on the low side; measured number outside the range, above it.
By their numbers in this assay, from the lowest: compounds 1 and 3 (each within the scatter of the next); then compound 4. At a limit, above all of these: compound 2.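

In this assay, replacing diethylamino with pyrrolidin-1-yl gives a modest step, a 5.2-fold higher number from compound 3 to compound 4 (0.72 log units; beyond the scatter), although the two groups have the same heavy-atom count and differ in that the second closes a ring. Having a ring does not by itself set the number: the step of a 9.1-fold higher number from compound 1 to compound 4 (0.96 log units; beyond the scatter) is also modest, while compound 1 also carries a ring amine, 2-methylpiperidin-1-yl, and cannot be ranked against open-chain compound 3, so pyrrolidin-1-yl is the group that stands apart among these three compounds. The step of an at least 1.6-fold lower number from compound 2 to compound 4 (0.21 log units; that floor lies within the scatter), which puts chloro in place of methyl on an aromatic carbon, cannot be read further because compound 2 stands at a limit: the limit of > 100000 nM in this assay, at which 1 of the 4 values shown sits.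

From the compounds shown here alone, what remains open is whether the gap follows from ring size or from the methyl group of 2-methylpiperidin-1-yl, a question that a plain piperidin-1-yl on the same propyl chain would address. A morpholin-4-yl group in that place would show whether a second hetero atom in the ring matters, and nothing shown explains why pyrrolidin-1-yl gives the higher number.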